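The source may report more compounds than this note shows. Statements on the series, on what has been measured and on what is new or still open speak of the compounds shown alone.

Compound 1, `COC(=O)C1(c2ccc(NC(=O)Nc3cccnc3Oc3ccccc3C(C)(C)C)cc2)CC1`, gives 7 nM in an assay on isolated protein for binding affinity to P2Y purinoceptor 1 (Homo sapiens); on this read-out lower numbers stand for stronger inhibition and higher numbers for weaker inhibition.
Compound 2, `CC(C)(C)c1ccccc1Oc1ncccc1NC(=O)Nc1ccc(C2(CO)CC2)cc1`, gives 176 nM in this assay.
Compound 3, `CC(C)(C)c1ccccc1Oc1ncccc1NC(=O)Nc1ccc(N2CCCCC2)cc1`, gives 11 nM in this assay.

All three share the same core, a urea linking two aromatic rings, and differ only in the group on one of those rings. Compound 3 carries a piperidin-1-yl there and sits second highest of the three numbers; its nearest neighbour is compound 1, with a 1.6-fold higher number from compound 1 to compound 3 (0.20 log units; within the scatter), a gap within the scatter, and its furthest is compound 2, with a 16-fold lower number from compound 2 to compound 3 (1.20 log units; beyond the scatter).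

Compound 4, `CN(C)CC(C)(C)COc1ccc(NC(=O)Nc2cccnc2Oc2ccccc2C(C)(C)C)cc1`, is not yet measured. It differs from compound 3 in one place: 2-((dimethylamino)methyl)-2-methylpropoxy in place of piperidin-1-yl on an aromatic carbon. Going by the values given here, no measured step tests this exact change. The two steps that bear on it show that swapping groups at this position can leave the number essentially unchanged, as from compound 1 to compound 3, or shift it widely, as with a 25-fold higher number from compound 1 to compound 2 (1.40 log units; beyond the scatter) and a 16-fold lower number from compound 2 to compound 3 (1.20 log units; beyond the scatter). So the range of plausible outcomes is broad, and a modest weakening is the expectation for compound 4, with a 2.7-fold higher number from compound 3 to compound 4 (0.44 log units; beyond the scatter), because the shift seen in a 16-fold lower number from compound 2 to compound 3 (1.20 log units; beyond the scatter) shows how far this position can move the read-out. The estimate for compound 4 in this assay is 30 nM, within 6 nM to 150 nM.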

Compound 4, inhibition constant: 137 nM
Estimate against measurement, compound 4: 4.6-fold (0.66 log units) below; measured number inside the range.
By their numbers in this assay, from the lowest: compounds 1 and 3 (each within the scatter of the next); then compounds 4 and 2 (each within the scatter of the next).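

Replacing piperidin-1-yl with 2-((dimethylamino)methyl)-2-methylpropoxy on this aromatic carbon gives a large loss in this assay (a 12-fold higher number from compound 3 to compound 4 (1.10 log units; beyond the scatter)), so the nitrogen carried by both groups is not enough on its own to keep the number low. The new group also lies far from 1-(methoxycarbonyl)cyclopropyl (a 20-fold higher number from compound 1 to compound 4 (1.29 log units; beyond the scatter)) but within the scatter of 1-(hydroxymethyl)cyclopropyl (a 1.3-fold lower number from compound 2 to compound 4 (0.11 log units; within the scatter)), so the four compounds fall into two sets, with compound 1 and compound 3 at low numbers and compound 2 and compound 4 at high numbers. Two quite different groups can therefore end up at the same level here, and nothing shown gives a reason for this split.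

The change swaps a ring for an open chain, adds an ether oxygen and moves the nitrogen further from the aromatic ring all at once, and the compounds shown do not say which of these matters. A shorter chain ending in dimethylamino, or the same chain ending in a piperidine ring or a carboxylic acid, would help to pull these apart.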